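Replacing the prenyl ether of compound 2 with an aryl carbamate

The source may report more compounds than this note shows. Statements on the series, on what has been measured and on what is new or still open speak of the compounds shown alone.

Compound 2 `CC(C)=CCC/C(C)=C/CC1Cc2c(OCC=C(C)C)cc(=O)n(CCCO)c2CC1(C)C` stands second highest of the three measured numbers in a functional assay on PANC-1 cells (Homo sapiens) for inhibition, read by MTT assay, with a stated time of 24 h, tested at 10 uM (a higher number here means more inhibition at the concentration tested (going by the name of the read-out), a lower number less inhibition), with compound 2 giving 30.3%. Compound 1 `CC(C)=CCOc1cc(=O)n(CCCO)c2c1CC(CC=C(C)C)C(C)(C)C2` gives 20.7%, and the step of a number 9.6 percentage points higher from compound 1 to compound 2 (within the scatter) is within the scatter. Compound 3 `COc1ccc(C(=O)NCCCOc2cc(=O)n(CCCO)c3c2CC(C/C=C(\C)CCC=C(C)C)C(C)(C)C3)cc1` gives 45.7%, which lies beyond the scatter above compound 2. Compound 4 `COc1ccccc1NC(=O)Oc1cc(=O)n(CCCO)c2c1CC(C/C=C(\C)CCC=C(C)C)C(C)(C)C2` differs from compound 2 by (2-methoxyphenyl)carbamoyl in place of 3-methylbut-2-en-1-yl on an oxygen on an aromatic ring. Going by the values given here, no measured step alters this oxygen directly; the only comparison is that compound 3, which also carries a methoxyphenyl-bearing group on that oxygen, is higher than compound 2. For compound 4 a moderate rise in this assay is therefore expected, a number 11.7 percentage points higher from compound 2 to compound 4 (beyond the scatter), giving an estimated 42% within a range of 25% to 60%.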

Compound 4, a percentage reported as inhibition, at one concentration (the size of the read-out at that concentration, not a potency): 53%
Estimate against measurement, compound 4: 11 percentage points below, within the range that was stated.
By their numbers in this assay, from the lowest: compounds 1 and 2 (each within the scatter of the next); then compounds 3 and 4 (each within the scatter of the next).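

In this assay, (2-methoxyphenyl)carbamoyl in place of 3-methylbut-2-en-1-yl on an oxygen on an aromatic ring gives a number 22.7 percentage points higher from compound 2 to compound 4 (beyond the scatter). Going by these compounds alone, this is the first measured step at this oxygen, and it shows that a change here can move the inhibition at the concentration tested beyond the scatter, which the earlier step on a saturated chain carbon did not do. Nothing measured here explains the rise.

As far as these compounds go, whether it comes from the carbamoyl or from the 2-methoxyphenyl group stays open. So does what a plain phenylcarbamoyl, an acetyl group or a free hydroxyl on this oxygen would give.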